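Exchanging the Sulfur-Linked Ring: What to Expect for Compound 4

The source may hold more compounds than are shown below. What is called first, only, known or untested is meant among the compounds shown, and "the series" means these compounds.

Of the compounds shown here, three have been tested in a functional assay on C6 cells (Rattus norvegicus) for cytotoxicity, read by MTT assay, with a stated time of 24 h, tested at 12 ug/mL; on this read-out lower numbers stand for a stronger effect and higher numbers for a weaker effect at the one concentration tested. Compound 1 `O=C(CSc1ncccn1)N/N=c1/scc(-c2ccc(Br)cc2)n1-c1ccccc1` gives 72.1%. Compound 2 `O=C(CSc1ncccn1)N/N=c1/scc(-c2ccc(F)cc2)n1-c1ccccc1` gives 77.4%. Within the data shown here, the only step measured so far, fluoro in place of bromo on an aromatic carbon, reads a number 5.3 percentage points higher from compound 1 to compound 2 (within the scatter). Compound 3 `Cc1nnc(SCC(=O)N/N=c2/scc(-c3ccc(Cl)cc3)n2-c2ccccc2)s1` gives 76.6%, the second highest of the three numbers; its nearest neighbour is compound 2 and its furthest is compound 1, and both gaps sit within the scatter, so no order can be read among these three.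

Compound 4 `O=C(CSc1ncccn1)N/N=c1/scc(-c2ccc(Cl)cc2)n1-c1ccccc1` has not yet been measured. It differs from compound 3 in one place: pyrimidin-2-yl in place of 5-methyl-1,3,4-thiadiazol-2-yl on a sulfur. Among the measured compounds shown here, no measured step touches this place, and the one step that has been measured is itself within the scatter. Compounds 1 and 2 already carry the pyrimidin-2-yl group that enters here, and their numbers lie close to that of compound 3. Compound 4 is therefore expected to show no step beyond the scatter, a number 1.6 percentage points lower from compound 3 to compound 4 (within the scatter). The estimate for compound 4 is 75%, with a range from 64% to 86%.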

Compound 4, a percentage reported as activity, at one concentration (the size of the read-out at that concentration, not a potency): 91.6%
Compound 4: middle estimate off by 16.6 percentage points, on the low side; measured number outside the range, above it.
By their numbers in this assay, from the lowest: compounds 1, 3 and 2 (each within the scatter of the next); then compound 4.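

In this assay, the ring on the sulfur is shown for the first time to matter: the record gives a number 15 percentage points higher from compound 3 to compound 4 (beyond the scatter) and so a weaker effect once pyrimidin-2-yl takes the place of 5-methyl-1,3,4-thiadiazol-2-yl. With pyrimidin-2-yl held on the sulfur, the halogen on the aromatic carbon matters as well, with a number 14.2 percentage points higher from compound 2 to compound 4 (beyond the scatter) and a number 19.5 percentage points higher from compound 1 to compound 4 (beyond the scatter) even though a number 5.3 percentage points higher from compound 1 to compound 2 (within the scatter) shows no real change, so chloro stands apart from both fluoro and bromo here. Compound 4 therefore has the weakest effect of the four, and the calm among the earlier numbers did not carry over to this combination.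

Still open, from the compounds shown here alone, is whether the ring exchange would give a similar step with bromo or fluoro on the aromatic carbon, and how a pyridin-2-yl or imidazol-2-yl group on that sulfur would read. No measurement at hand offers an explanation for this result.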